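The source may hold more compounds than are shown below. What is called first, only, known or untested is meant among the compounds shown, and "the series" means these compounds.

Measured compounds:
- compound 1, `CC(Sc1nc2c(cnn2C)c(=O)n1-c1ccccc1)c1cccc(F)c1`: 151 nM
- compound 2, `CC(Sc1nc2nn(C3COC3)cc2c(=O)n1-c1ccccc1)c1ccccn1`: 68 nM
- compound 3, `CC(Sc1nc2nn(CC3COC3)cc2c(=O)n1-c1ccccc1)c1ccccc1`: 100 nM

All three numbers come from an assay on isolated protein for inhibition of aldehyde dehydrogenase 1A1 (Homo sapiens); on this read-out lower numbers stand for stronger inhibition and higher numbers for weaker inhibition. Among them compound 1 carries the highest number. Against compound 3 the gap is within the usual scatter, so the two cannot be told apart on these data. Against compound 2 the gap lies beyond the scatter, and compound 2 shows the lower number of the pair. Compounds 2 and 3 differ from compound 1 in more than one place, so no single step can be read from them.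

Compound 4, `CC(Sc1nc2c(cnn2C)c(=O)n1-c1ccccc1)c1ccncc1`, is not yet measured. It differs from compound 1 in one place: pyridin-4-yl in place of 3-fluorophenyl on a saturated chain carbon bound to a saturated chain carbon and a sulfur. For the measured compounds named here, no measured pair in this set isolates this change, and the two compounds that do carry a pyridinyl or phenyl group at this position also differ elsewhere in the core, so they give no clean guide.

For compound 4 the expectation in this assay is a step of a 1.3-fold higher number from compound 1 to compound 4 (0.12 log units; within the scatter), which is no step beyond the scatter. Compound 4 is estimated at 200 nM, with a range from 80 nM to 500 nM.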

Compound 4, half-maximal inhibitory concentration: 451 nM
The estimate for compound 4 lay 2.3-fold (0.35 log units) below the measured number, and the stated range covers the measured number.
By their numbers in this assay, from the lowest: compounds 2, 3 and 1 (each within the scatter of the next, the first and the last beyond it); then compound 4.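

In this assay, for the compounds shown here, the place on a saturated chain carbon bound to a saturated chain carbon and a sulfur proves sensitive to the choice of ring: pyridin-4-yl in place of 3-fluorophenyl gives a 3.0-fold higher number from compound 1 to compound 4 (0.48 log units; beyond the scatter) and provides the first single-place step, one beyond the usual scatter. The change replaces a carbon-only ring bearing fluorine with a ring holding one hetero atom and one hydrogen-bond acceptor, so this pair cannot separate the gain of the ring nitrogen from the loss of the fluorine. Nothing at hand bears on the origin of the step.

On these data alone, whether the step stems from the ring nitrogen, its location or the missing fluorine remains open, and pyridin-3-yl on the core of compound 1 would help to separate these. Also open, as far as these compounds go, is whether the same change has a similar effect on the cores of compound 2 and compound 3.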